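The source may report more compounds than this note shows. Statements on the series, on what has been measured and on what is new or still open speak of the compounds shown alone.

Compound 1 `COc1ccc(-c2nnc(SC/C(=N/O)c3ccccc3)n2-c2ccccc2)cc1OC`, compound 2 `CCn1c(SCC(=O)c2ccccc2)nnc1-c1cc(OC)c(OC)c(OC)c1` and compound 3 `CCn1c(SC/C(=N/O)c2ccccc2)nnc1-c1cc(OC)c(OC)c(OC)c1` share one core and have each been run in a functional assay on the whole organism (strain albino) for inhibition, with Rattus norvegicus as the target, read by paw edema, with a stated time of 3 h, at a dose of 0.28 mmol/kg by the oral route; on this read-out higher numbers stand for more inhibition at the one dose given (going by the name of the read-out) and lower numbers for less inhibition. In this assay compound 1 gives 67%, compound 2 gives 49% and compound 3 gives 69%. For the measured compounds named here, the only single-point change measured so far is a number 20 percentage points higher from compound 2 to compound 3 (beyond the scatter). Compound 3 thus carries the largest of the three numbers, with compound 1 within the usual scatter of it and compound 2 beyond it.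

Compound 4 `CCn1c(SC/C(=N/O)c2ccccc2)nnc1-c1ccc(OC)c(OC)c1` differs from compound 3 by hydrogen in place of methoxy on an aromatic carbon. Going by the values given here, no measured step bears directly on this change: the step from compound 2 to compound 3 concerns the chain on the sulfur, not the methoxy groups, and compound 1, which differs from compound 3 in more than one place, shows a number within the scatter of compound 3. The change is therefore expected to give no step beyond the scatter in this assay, a number 4 percentage points lower from compound 3 to compound 4 (within the scatter). Compound 4 is estimated at 65% in this assay, with a range from 50% to 78%.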

Compound 4, a percentage reported as inhibition, in the whole organism at one dose (the size of the read-out at that dose, not a potency): 71%
Estimate against measurement, compound 4: 6 percentage points below; the measured number falls inside the stated range.
By their numbers in this assay, from the lowest: compound 2; then compounds 1, 3 and 4 (each within the scatter of the next).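

In this assay, hydrogen in place of methoxy on this aromatic carbon gives a number 2 percentage points higher from compound 3 to compound 4 (within the scatter) and thus shows that the number holds without this methoxy group at the one dose given. Ethyl in place of phenyl on the aromatic nitrogen gives a number 4 percentage points higher from compound 1 to compound 4 (within the scatter) and provides the first single-place reading at that nitrogen, where the change likewise stays within the scatter. No measurement offers an explanation for either step.

From the compounds shown here alone, whether a hydroxyl group or chlorine on this aromatic carbon, or a propyl or benzyl group on the aromatic nitrogen, would shift the number remains open. A single dose and a single time also leave open whether compound 3 and compound 4 would stay this close at lower doses or at other times.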